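A few compounds are considered here, and "the series" means these few. Any claim that something is new, unique, unknown or untested is made for them only; others in the source may bear on it.

In an ADME assay (liver) for pharmacokinetics, with Liver microsome (Rattus norvegicus) as the target, read by LC-MS, using microsomes, tested at 2 uM (a higher number here means faster removal of the compound, a lower number slower removal), compound 3 (`CN(CC1CC1)c1ncc(C(=O)N[C@@H]2CCCC[C@H]2O)cc1-c1ccc(Cl)cc1`) gives 1.73 mL/min/kg as the highest of the three numbers, against compound 1 (`COCCOc1ncc(C(=O)N[C@@H]2CCCC[C@H]2O)cc1-c1ccc(Cl)cc1`) at 0.098 mL/min/kg and compound 2 (`O=C(N[C@@H]1CCCC[C@H]1O)c1cnc(OCc2ccncc2)c(-c2ccc(Cl)cc2)c1`) at 0.118 mL/min/kg on the same scale. Compound 4 (`O=C(N[C@@H]1CCCC[C@H]1O)c1cnc(CCC2CC2)c(-c2ccc(Cl)cc2)c1`) differs from compound 3 as follows: 2-cyclopropylethyl in place of (cyclopropylmethyl)(methyl)amino on an aromatic carbon on the shared core. The relevant measured changes at this aromatic carbon are an 18-fold higher number from compound 1 to compound 3 (1.25 log units; beyond the scatter) and a 15-fold higher number from compound 2 to compound 3 (1.17 log units; beyond the scatter) and both are large, while a 1.2-fold higher number from compound 1 to compound 2 (0.08 log units; within the scatter) stays within the scatter. Among the compounds with values here, none of the measured compounds carries 2-cyclopropylethyl, so the data support no direction and no step beyond the scatter is expected. The expected change is a 1.2-fold lower number from compound 3 to compound 4 (0.06 log units; within the scatter) on this estimate. In this assay compound 4 is estimated at 1.5 mL/min/kg with a range from 0.3 mL/min/kg to 6 mL/min/kg as the expected span.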

Compound 4, clearance: 1.5 mL/min/kg
Compound 4: middle estimate and measured number agree at the digits printed; low and high end bracket the measured number.
By their numbers in this assay, from the lowest: compounds 1 and 2 (each within the scatter of the next); then compounds 4 and 3 (each within the scatter of the next).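

In this assay the step of a 1.2-fold lower number from compound 3 to compound 4 (0.06 log units; within the scatter) shows that, on this aromatic carbon next to the ring nitrogen, 2-cyclopropylethyl can replace (cyclopropylmethyl)(methyl)amino without a change beyond the scatter. The steps of a 13-fold higher number from compound 2 to compound 4 (1.10 log units; beyond the scatter) and a 15-fold higher number from compound 1 to compound 4 (1.18 log units; beyond the scatter) place 2-cyclopropylethyl with the amine, so among these four compounds the two lowest numbers belong to the groups bound through oxygen. No measurement shown gives a cause for this gap. Still open, from the compounds shown here alone, is whether the linking oxygen or the rest of each group carries the gap. A cyclopropylmethoxy group on this carbon would bear on that question.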